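The compounds below may be only part of what the source reports. "The series", "measured", "known", "first", "only" and "open" are said of these compounds alone.

Three compounds share a common core and differ in the group attached to it. Compound 1 `CCC1C(=O)N(C)c2cnc(-n3ccc4cc(C(N)=O)ccc43)nc2N1c1ccn(C)n1` carries an amide-bearing bicyclic group and in an assay for inhibition of serine/threonine-protein kinase PLK2 (Homo sapiens), read by FRET and Z'-LYTE, with a stated time of 1 h (a higher number here means a weaker inhibitor, a lower number a stronger inhibitor), compound 1 gives 384 nM. Compound 2 `CCC1C(=O)N(C)c2cnc(Nc3ccc(S(=O)(=O)NCCCO)cc3)nc2N1c1ccn(C)n1` instead bears an anilino sulfonamide and in this assay compound 2 gives 192 nM. Compound 3 `CCC1C(=O)N(C)c2cnc(Nc3ccc(S(=O)(=O)NCC(C)C)cc3)nc2N1c1ccn(C)n1` keeps that sulfonamide and in this assay compound 3 gives 311 nM, which sits within the scatter of both other numbers, so no ordering among the three can be read from them. Going by the values given here, the only single-point step measured, a 1.6-fold higher number from compound 2 to compound 3 (0.21 log units; within the scatter), shows that swapping a polar substituent for a plain hydrocarbon on the sulfonamide chain left the number essentially unchanged.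

Compound 4 `CCCCNS(=O)(=O)c1ccc(Nc2ncc3c(n2)N(c2ccn(C)n2)C(CC)C(=O)N3C)cc1` is built from the same atoms as compound 3, joined differently: propyl in place of isopropyl on a saturated chain carbon bound to a sulfonamide nitrogen. Since the larger change from compound 2 to compound 3 stayed within the scatter, a mere straightening of a three-carbon chain is expected to do the same, giving an estimated step of a 1.0-fold lower number from compound 3 to compound 4 (0.02 log units; within the scatter). Compound 4 is therefore expected to give about 300 nM in this assay, likely between 150 nM and 600 nM.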

Compound 4, half-maximal inhibitory concentration: 191 nM
The estimate for compound 4 lay 1.6-fold (0.20 log units) above the measured number, within the range that was stated.
By their numbers in this assay, from the lowest: compounds 4, 2, 3 and 1 (each within the scatter of the next).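

The change from isobutylsulfamoyl to butylsulfamoyl gives a 1.6-fold lower number from compound 3 to compound 4 (0.21 log units; within the scatter), so in this assay removing the branch from this chain has no effect that can be told from the scatter. Methyl in place of hydroxy on a saturated chain carbon, three bonds along the chain from a sulfonamide nitrogen, gives a 1.0-fold lower number from compound 2 to compound 4 (0.00 log units; within the scatter), a direct comparison of those two groups that the earlier compounds did not offer, and it too shows no readable effect. No supporting data are available to explain either result.

As far as these compounds go, what remains open is whether any group on this chain can shift the number beyond the scatter. An amine or a carboxylic acid in place of that hydroxy, or a longer chain such as hexyl, would test this.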